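The compounds below may be only part of what the source reports. "The series", "measured", "known", "first", "only" and "open" are said of these compounds alone.

Measured compounds:
compound 1 `CCN(Cc1cccnc1)c1ccc(C(=O)N2CCc3ccc(OS(N)(=O)=O)cc3C2)cc1` — 35.7%
compound 2 `CCN(Cc1ccccn1)c1ccc(C(=O)N2CCc3ccc(OS(N)(=O)=O)cc3C2)cc1` — 42.5%
compound 3 `CCN(Cc1ccc(Br)cc1)c1ccc(C(=O)N2CCc3ccc(OS(N)(=O)=O)cc3C2)cc1` — 78.2%

The read-out throughout is an assay on HEK293 cells for inhibition of Steryl-sulfatase (Homo sapiens), tested at 0.1 uM; on this read-out higher numbers stand for a stronger effect at the one concentration tested and lower numbers for a weaker effect. Compound 3 gives the highest number of the three; its nearest neighbour is compound 2, a number 35.7 percentage points higher from compound 2 to compound 3 (beyond the scatter), and compound 1 lies furthest, a number 42.5 percentage points higher from compound 1 to compound 3 (beyond the scatter). Between compound 1 and compound 2 the change is a number 6.8 percentage points higher from compound 1 to compound 2 (within the scatter).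

Compound 4 `NS(=O)(=O)Oc1ccc2c(c1)CN(C(=O)c1ccc(N3CCCCC3)cc1)CC2` is not yet measured. It differs from compound 3 in one place: piperidin-1-yl in place of (4-bromobenzyl)(ethyl)amino on an aromatic carbon. Going by the values given here, no measured step exchanges this whole amino substituent; the measured steps only exchange the ring on a saturated chain carbon bound to a nitrogen on an aromatic ring, and they show that this region moves the read-out by large amounts, a number 42.5 percentage points higher from compound 1 to compound 3 (beyond the scatter) and a number 35.7 percentage points higher from compound 2 to compound 3 (beyond the scatter). Compound 4 keeps none of the three ring variants and has no benzyl arm at all, so a downward step of similar order is expected: a number 48.2 percentage points lower from compound 3 to compound 4 (beyond the scatter). The estimate for compound 4 in this assay is 30%, with a range from 8% to 58%.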

Compound 4, a percentage reported as inhibition, at one concentration (the size of the read-out at that concentration, not a potency): 11.5%
The estimate for compound 4 lay 18.5 percentage points above the measured number; low and high end bracket the measured number.
By their numbers in this assay, from the lowest: compound 4; then compounds 1 and 2 (each within the scatter of the next); then compound 3.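

In this assay piperidin-1-yl in place of (4-bromobenzyl)(ethyl)amino on the aromatic carbon gives a number 66.7 percentage points lower from compound 3 to compound 4 (beyond the scatter) and so shows that exchanging the whole amino substituent moves the read-out further than any exchange of the ring on its chain carbon. The piperidin-1-yl compound also lies under both pyridine-bearing compounds, with a number 31 percentage points lower from compound 2 to compound 4 (beyond the scatter) and a number 24.2 percentage points lower from compound 1 to compound 4 (beyond the scatter) as the steps, so the benzyl-type arm keeps more effect than the closed ring even without bromine. Nothing at hand accounts for these drops.

Going by these compounds, how much of the gain rests on the bromine and how much on the open ethyl and benzyl arm stays open, and plain benzyl or 4-chlorobenzyl on the same nitrogen would separate the two. On these data alone, whether morpholin-4-yl or diethylamino would behave like piperidin-1-yl also remains open.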